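Acetyl in place of dimethylamino on a pyrazole series

A few compounds are considered here, and "the series" means these few. Any claim that something is new, unique, unknown or untested is made for them only; others in the source may bear on it.

Measured compounds:
compound 1, `COc1cc(C)cc(-c2c(-c3ccnc(-c4ccc(N(C)C)cc4)c3)cnn2CC#N)c1`, 1040 nM
compound 2, `COc1cc(C)cc(-c2nn(CC#N)cc2-c2ccnc(-c3ccc(N(C)C)cc3)c2)c1`, 7240 nM
compound 3, `COc1cc(C)cc(-c2nn(CC#N)cc2-c2ccc(-c3cccc(C(C)=O)c3)nc2)c1`, 52300 nM

In a functional assay on MDA-MB-468 cells (Homo sapiens) for inhibition, read by sulforhodamine B assay, with a stated time of 48 h (a lower number here means that less compound is tolerated, a higher number that more compound is tolerated), compound 1 gives the lowest of the three numbers. Compound 2 lies higher, beyond the scatter, and compound 3 lies higher still, also beyond the scatter. Compound 4, `COc1cc(C)cc(-c2c(-c3ccnc(-c4ccc(C(C)=O)cc4)c3)cnn2CC#N)c1`, is not yet measured. It differs from compound 1 in one place: acetyl in place of dimethylamino on an aromatic carbon. For the measured compounds named here, no pair of measured compounds differs by this single change, so the size of the step has to be estimated. Compound 3 carries an acetyl on a phenyl ring and gives 52300 nM in this assay, but it also differs from compound 1 in other respects, so it is only a rough guide. The step from compound 1 to compound 4 is expected to be upward and beyond the scatter, a 7.7-fold higher number from compound 1 to compound 4 (0.89 log units; beyond the scatter). Compound 4 is accordingly expected to give about 8000 nM, within a range from 2000 nM to 30000 nM.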

Compound 4, concentration lethal to 50% of the cells: 2130 nM
The estimate for compound 4 lay 3.8-fold (0.57 log units) above the measured number, and the stated range covers the measured number.
By their numbers in this assay, from the lowest: compound 1; then compound 4; then compound 2; then compound 3.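

In this assay, for the compounds shown here, 4-acetylphenyl in place of 4-(dimethylamino)phenyl gives a 2.0-fold higher number from compound 1 to compound 4 (0.31 log units; beyond the scatter) and so counts as a modest step, the first reading of a single change in this set. At this place, on an aromatic carbon para to a large group, the exchange keeps the count of 3 heavy atoms and of 1 hydrogen-bond acceptor, yet swaps nitrogen for oxygen and brings in a double bond outside the aromatic rings, and the number moves only a little. No measurement at hand accounts for the size of this step.

The compounds shown leave open how a primary amine, a carboxylic acid or a longer chain would read at this same place. They also leave open whether acetyl in place of dimethylamino would give a step of similar size on the core of compound 2.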